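A Methoxy Group in Place of Bromine on a Triazole-Linked Phenyl

The source may report more compounds than this note shows. Statements on the series, on what has been measured and on what is new or still open speak of the compounds shown alone.

Of the compounds shown here, two sharing one core have so far been tested. Compound 1 `O=C1O[C@H]([C@@H](O)Cn2cc(-c3ccc(Br)cc3)nn2)C(OCc2ccccc2)=C1OCc1ccccc1` is measured in a functional assay on A549 cells (Homo sapiens) for antiproliferative activity, read by MTT assay, with a stated time of 72 h (on this read-out higher numbers stand for weaker inhibition and lower numbers for stronger inhibition), at 750 nM. Compound 2 `O=C1O[C@H]([C@@H](O)Cn2cc(-c3cc(C(F)(F)F)cc(C(F)(F)F)c3)nn2)C(OCc2ccccc2)=C1OCc1ccccc1`, which carries a bis(trifluoromethyl)phenyl group instead, gives in this assay a value of 28900 nM. Compound 1 therefore stands at the lower, stronger end of the two numbers shown, and the gap to compound 2 lies well beyond the scatter of the method.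

Compound 3 `COc1ccccc1-c1cn(C[C@H](O)[C@H]2OC(=O)C(OCc3ccccc3)=C2OCc2ccccc2)nn1` has not yet been measured. It differs from compound 1 in one place: 2-methoxyphenyl in place of 4-bromophenyl on an aromatic carbon. Among the compounds with values here, the single measured change on this phenyl ring, that from compound 1 to compound 2, cost a great deal of activity, so a change at the same position is approached with caution, though the new group is smaller than the one in compound 2.

Compound 3 is expected to be somewhat weaker than compound 1, with the step of a 3.3-fold higher number from compound 1 to compound 3 (0.52 log units; beyond the scatter) estimated to be modest and close to the edge of the scatter. The estimate for compound 3 in this assay is 2500 nM, within a range from 600 nM to 12000 nM.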

Compound 3, half-maximal inhibitory concentration: > 100000 nM
Compound 3 ended at the assay's limit; the forecaster's own chance of this, stated with the estimate: 5%; middle value at least 40-fold (1.60 log units) from the limit.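

The reading of compound 3 in this assay is a limit of the assay and not a number: the limit of > 100000 nM in this assay, at which 1 of the 3 values shown sits. Replacing 4-bromophenyl with 2-methoxyphenyl on this aromatic carbon gives a large loss, an at least 130-fold higher number from compound 1 to compound 3 (2.12 log units; beyond the scatter), and the real gap could be wider still. Within the data shown here, until now the only weak compound was compound 2, with its bis(trifluoromethyl)phenyl group, whereas compound 3 shows that activity at this place can also vanish with a single methoxy substituent on the phenyl ring, so the position tolerates much less change than one earlier comparison could reveal.

This change alters two things at once, the kind of substituent and where it sits on the phenyl ring, and the compounds shown cannot separate the two. A 4-methoxyphenyl or a 2-bromophenyl group on the same core would tell which of these matters, and a 4-aminophenyl group would show whether anything other than bromine is accepted at that ring position.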